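The source may report more compounds than this note shows. Statements on the series, on what has been measured and on what is new or still open speak of the compounds shown alone.

Compounds measured so far:
compound 1, `COc1ccc(-c2cnc3nc(N)nc(N4CCN(C(=O)c5ccccc5)CC4)c3n2)cc1OC`, 400 nM in a functional assay on cells (T-cell, Homo sapiens) for inhibition; on this read-out lower numbers stand for stronger inhibition and higher numbers for weaker inhibition;
compound 2, `COc1ccc(-c2cnc3nc(N)nc(N4CCN(c5ccc(C)cc5)CC4)c3n2)cc1OC`, 300 nM.

Compound 2 has the lowest of the two numbers, yet its nearest neighbour, compound 1, lies within the scatter. Among the compounds with values here, the only measured step, a 1.3-fold lower number from compound 1 to compound 2 (0.12 log units; within the scatter), was small. Compound 3, `COc1ccc(-c2cnc3nc(N)nc(N4CCN(C(=O)Nc5cccc(C)c5)CC4)c3n2)cc1OC`, carries the change ((3-methylphenyl)carbamoyl in place of 4-methylphenyl on an amine nitrogen in a ring). Since the exchange of benzoyl for 4-methylphenyl moved little, the return to a carbonyl-bearing group at the same ring nitrogen is expected to move little as well: the step of a 1.2-fold higher number from compound 2 to compound 3 (0.07 log units; within the scatter) is estimated to stay within the scatter. For compound 3 the value is estimated at 350 nM, ranging from 150 nM to 900 nM.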

Compound 3, half-maximal inhibitory concentration: 7 nM
The estimate for compound 3 lay 50-fold (1.70 log units) above the measured number; measured number outside the range, below it.
By their numbers in this assay, from the lowest: compound 3; then compounds 2 and 1 (each within the scatter of the next).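

In this assay this amine nitrogen in a ring proved far more sensitive than the earlier step suggested: (3-methylphenyl)carbamoyl in place of 4-methylphenyl gives a 43-fold lower number from compound 2 to compound 3 (1.63 log units; beyond the scatter) and (3-methylphenyl)amino in place of phenyl on a carbonyl carbon gives a 57-fold lower number from compound 1 to compound 3 (1.76 log units; beyond the scatter) as well. A carbonyl on this nitrogen is thus not enough for the low number, since compound 1 carries one too. Nothing available explains the step. Going by these compounds, whether the amide hydrogen or the methyl on the phenyl ring matters remains open; an unsubstituted phenylamino or a cyclohexylamino group on the carbonyl carbon would bear on this.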